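The source may report more compounds than this note shows. Statements on the series, on what has been measured and on what is new or still open speak of the compounds shown alone.

Measured compounds in an ADME assay on MRC5 cells (Homo sapiens) for cytotoxicity, read by fluorescence and resazurin assay, with a stated time of 3 days; on this read-out higher numbers stand for weaker inhibition and lower numbers for stronger inhibition:

compound 1 `Cc1cn(C2CCN(Cc3cc(Oc4cc(Cl)cc(Cl)c4)ccn3)CC2)c(=O)[nH]c1=O` — "not determined" (no result reported)
compound 2 `Cc1cn(C2CCN(Cc3cccc(Oc4cccc(Cl)c4)c3)CC2)c(=O)[nH]c1=O` — 21000 nM
compound 3 `Cc1cn(C2CCN(Cc3ccnc(Oc4cccc(Cl)c4)c3)CC2)c(=O)[nH]c1=O` — > 64000 nM

In this assay, within the data shown here, compound 2 gives 21000 nM, the only plain number in the set. Compound 3 gives > 64000 nM, which is a limit of the assay and not a number; this is the limit of > 64000 nM in this assay, at which 1 of the 3 values shown sits. Compound 1 has no reported result. Among the measured compounds shown here, with one number, one limit and one blank, no comparison between compounds gives a sized step, and no pattern is claimed.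

Compound 4 `Cc1cn(C2CCN(Cc3cccc(Oc4ccc(Cl)c(C(F)(F)F)c4)c3)CC2)c(=O)[nH]c1=O` is to be measured in this assay. It differs from compound 2 in one place: 4-chloro-3-(trifluoromethyl)phenyl in place of 3-chlorophenyl on an oxygen on an aromatic ring.

For the measured compounds named here, no step between two measured compounds of this kind is available to calibrate the change. The expectation for a 1.3-fold lower number from compound 2 to compound 4 (0.12 log units; within the scatter) is a step no larger than the scatter, without a confident direction. On that basis compound 4 is estimated at 16000 nM, with the range 5000 nM to 50000 nM in this assay.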

Compound 4, half-maximal inhibitory concentration: 5280 nM
Compound 4: middle estimate off by 3.0-fold (0.48 log units), on the high side; low and high end bracket the measured number.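

In this assay, among these compounds, the change from 3-chlorophenyl to 4-chloro-3-(trifluoromethyl)phenyl on an oxygen on an aromatic ring gives a 4.0-fold lower number from compound 2 to compound 4 (0.60 log units; beyond the scatter) and this is the first sized step. With the core of compound 2 kept, a change at this place alone therefore moves the cytotoxicity read-out toward stronger inhibition, by a modest amount. No measurement shown gives a cause for this step.

Whether the step belongs to the trifluoromethyl group or to the changed place of the chlorine stays open, as no compound shown separates the two. From the compounds shown here alone, how a nitrile or a methoxy group on this ring would read in this assay also stays open.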